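The source may report more compounds than this note shows. Statements on the series, on what has been measured and on what is new or still open speak of the compounds shown alone.

Compound 1 `COc1ccc(NC(=O)NC2CC(C)(C)Oc3ccc(F)cc32)cc1` carries a 4-methoxyphenyl on the urea of the shared core. In a functional assay (aorta) with Rattus norvegicus as the target (a lower number here means that less compound is needed, a higher number that more compound is needed for the effect), compound 1 gives 15500 nM. Compound 2 `Cc1ccccc1NC(=O)NC1CC(C)(C)Oc2ccc(F)cc21` carries a 2-methylphenyl instead; in this assay compound 2 reaches only the limit > 30000 nM. Compound 3 `Cc1ccc(NC(=O)NC2CC(C)(C)Oc3ccc(F)cc32)cc1` carries a 4-methylphenyl; in this assay compound 3 likewise reaches only the limit > 30000 nM, so compound 3 stands at the limit of > 30000 nM in this assay, at which 2 of the 3 values shown sit. The steps of an at least 1.9-fold higher number from compound 1 to compound 2 (0.28 log units; that floor lies within the scatter) and an at least 1.9-fold higher number from compound 1 to compound 3 (0.28 log units; that floor lies within the scatter) are floors, and the step that the two limits leave unreadable from compound 2 to compound 3 cannot be read. Compound 4 `CC1(C)CC(NC(=O)Nc2ccccc2Cl)c2cc(F)ccc2O1` differs from compound 3 by 2-chlorophenyl in place of 4-methylphenyl on an amide-type nitrogen. With both neighbouring limits, the step that the limit leaves unreadable from compound 3 to compound 4 is expected to stay unreadable, and compound 4 is estimated to give 40000 nM, between 12000 nM and 120000 nM, most likely again as a limit.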

Compound 4, half-maximal effective concentration: > 30000 nM
Compound 4 gave a limit, no number (the forecaster's own chance of this, stated with the estimate: 70%); the middle value does not contradict the limit.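

In this assay compound 4 gives > 30000 nM, which is a limit and not a number, so a 2-chlorophenyl on the amide-type nitrogen also yields no measurable value. Within the data shown here, the one readable step is an at least 1.9-fold higher number from compound 1 to compound 4 (0.28 log units; that floor lies within the scatter), while the steps among the three limits cannot be read. Compound 1 remains the only compound with a number, and the other values share one limit: the limit of > 30000 nM in this assay, at which 3 of the 4 values shown sit.

On these data alone, it remains open whether any replacement for the 4-methoxyphenyl gives a readable value. An amine or a carboxylic acid on the phenyl group is one such untested case.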